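A few compounds are considered here, and "the series" means these few. Any claim that something is new, unique, unknown or untested is made for them only; others in the source may bear on it.

Measured so far:
compound 1, `CCCCCCNC(=O)CCC(NS(=O)(=O)c1cc(Cl)ccc1Cl)C(=O)NCCCCCC`: 12.4%
compound 2, `CCCCCNC(=O)CCC(NS(=O)(=O)c1ccc(Cl)c(Cl)c1)C(=O)NCCCCC`: 20.8%
compound 3, `O=C(CCC(NS(=O)(=O)c1ccc(Cl)c(Cl)c1)C(=O)NC1CCCCC1)NC1CCCCC1`: 24%

In a functional assay on IMR-32 cells (Homo sapiens) for cytotoxicity, read by MTT assay, tested at 60 ug/mL (a higher number here means more inhibition at the concentration tested (going by the name of the read-out), a lower number less inhibition), compound 1 gives 12.4%, the lowest of the three numbers. Compound 2 gives 20.8%, a number that lies within the scatter of the value of compound 1, so no order between these two can be read. Compound 3 gives 24%, a number beyond the scatter above the value of compound 1; this is the only gap in the set that can be called a difference.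

Compound 4, `CCCCCCNC(=O)CCC(NS(=O)(=O)c1cc(C)ccc1Cl)C(=O)NCCCCCC`, has not been measured. It differs from compound 1 in one place: methyl in place of chloro on an aromatic carbon. Within the data shown here, no pair of measured compounds differs in a single place, so no measured step in this assay can be taken as a guide for a change of this kind. The change is small in what it counts, so the expected step of a number 1.6 percentage points higher from compound 1 to compound 4 (within the scatter) is small and not beyond the scatter, in either direction. Compound 4 is therefore estimated at 14%, with a range from 4% to 26%.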

Compound 4, a percentage reported as inhibition, at one concentration (the size of the read-out at that concentration, not a potency): 11.3%
Compound 4: middle estimate off by 2.7 percentage points, on the high side; low and high end bracket the measured number.
By their numbers in this assay, from the lowest: compounds 4, 1, 2 and 3 (each within the scatter of the next, the first and the last beyond it).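

Going from (2,5-dichlorophenyl)sulfonyl to (2-chloro-5-methylphenyl)sulfonyl in this assay gives a number 1.1 percentage points lower from compound 1 to compound 4 (within the scatter) and is the first step in the series that can be read at a single place. At this place on the ring, para to a chloro group, methyl in place of chloro therefore brings no readable difference, and a chloro group there is not needed for the number seen with compound 1. No measurement at hand speaks to the reason for this.

On these data alone, whether an amine or a carboxylic acid at this place would give a step beyond the scatter stays open. Also open, as far as these compounds go, is whether methyl in place of chloro reads the same way on compound 2 or compound 3, which carry other groups on the amides.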